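This account rests on a few compounds, and the source may have more. Where it says the series, first, only, none or still open, it means among the compounds named here.

Working notes on the series. Among the measured compounds shown here, in a functional assay on A549 cells (Homo sapiens) for inhibition, read by MTT assay, with a stated time of 48 h (a lower number here means a stronger inhibitor, a higher number a weaker inhibitor), compound 1 (`Oc1cccc(C(c2c[nH]c3ccc(Br)cc23)c2c[nH]c3ccc(Br)cc23)c1`) gives 8000 nM, while compound 2 (`CN(C)c1ccc(C(c2c[nH]c3ccc(Br)cc23)c2c[nH]c3ccc(Br)cc23)cc1`) gives 25000 nM, the higher of the two numbers so far and so the weaker inhibitor of the pair. Compound 3 (`CCCCCCCC(c1c[nH]c2ccc(Br)cc12)c1c[nH]c2ccc(Br)cc12`) carries heptyl in place of 4-(dimethylamino)phenyl on a saturated chain carbon bound to two aromatic carbons. For the measured compounds named here, only one measured step bears on this change, at the same carbon: a 3.1-fold higher number from compound 1 to compound 2 (0.49 log units; beyond the scatter). Going by the values given here, that step is modest and joins two ring-bearing groups, so no measurement yet covers a group with no ring. A modest step is therefore expected in this assay, tentatively towards a lower number, since compound 2 stands at the top of the two values, with the direction poorly supported. The expected step is a 2.1-fold lower number from compound 2 to compound 3 (0.32 log units; beyond the scatter). For compound 3 the estimated value is 12000 nM, with an expected range from 4000 nM to 40000 nM.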

Compound 3, half-maximal inhibitory concentration: 3500 nM
Estimate against measurement, compound 3: 3.4-fold (0.54 log units) above; measured number below the stated range.
By their numbers in this assay, from the lowest: compound 3; then compound 1; then compound 2.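

In this assay this position, on a saturated chain carbon bound to two aromatic carbons, accepts a group with no ring: heptyl gives a lower number than either ring-bearing group (a 7.1-fold lower number from compound 2 to compound 3 (0.85 log units; beyond the scatter); a 2.3-fold lower number from compound 1 to compound 3 (0.36 log units; beyond the scatter)). A ring at this carbon is thus not needed for activity in this series, and compound 3 is the strongest inhibitor of the three, with both of its steps beyond the scatter. No measurement on hand explains why heptyl outperforms 3-hydroxyphenyl and 4-(dimethylamino)phenyl here.

Heptyl is the only ringless group shown, so the compounds do not separate the absence of a ring from the particular chain. From the compounds shown here alone, whether a shorter chain, a longer chain, or a heptyl chain ending in an amine or a carboxylic acid would keep or lower the number remains open.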